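This account rests on a few compounds, and the source may have more. Where it says the series, first, only, none or still open, it means among the compounds named here.

Among the compounds with values here, compound 1, with the structure `Cc1cc(C(=O)NCc2ccncc2)nn1Cc1cc(Cl)ccc1OCc1ccccc1`, is one of two compounds measured in an assay on CHO-K1 cells for displacement of a labelled ligand from prostaglandin E2 receptor EP1 subtype (Homo sapiens) (on this read-out higher numbers stand for weaker inhibition and lower numbers for stronger inhibition), where compound 1 gives 79.4 nM. The other is compound 2, with the structure `Cc1cc(C(=O)NN2CCOCC2)nn1Cc1cc(Cl)ccc1OCC(C)C`; in this assay compound 2 gives 251 nM. Of these two numbers compound 1 has the lower one, and the gap to compound 2 is beyond the usual scatter, so compound 1 is the stronger binder of the pair on this read-out.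

The next compound, compound 3, has the structure `COC(=O)Nc1cc(C)n(Cc2cc(Cl)ccc2OCc2ccccc2)n1` and has not yet been measured. It differs from compound 1 in one place: (methoxycarbonyl)amino in place of ((pyridin-4-yl)methyl)carbamoyl on an aromatic carbon. A group with an aromatic ring is replaced by a much smaller group without a ring, so the part of the molecule that leaves is larger than what enters.

Within the data shown here, with only two measured compounds there is no measured step to lean on. The expectation is that this change weakens binding, with a step in this assay of a 5.0-fold higher number from compound 1 to compound 3 (0.70 log units; beyond the scatter) that goes beyond the scatter. Compound 3 is therefore estimated at 400 nM, with a likely range from 100 nM to 2000 nM.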

Compound 3, half-maximal inhibitory concentration: 200 nM
Compound 3: the middle estimate sits 2.0-fold (0.30 log units) above what was measured; the measured number falls inside the stated range.
By their numbers in this assay, from the lowest: compound 1; then compounds 3 and 2 (each within the scatter of the next).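

In this assay, the change on this aromatic carbon gives a 2.5-fold higher number from compound 1 to compound 3 (0.40 log units; beyond the scatter), a step beyond the scatter but a modest one. So binding on this read-out does not vanish when ((pyridin-4-yl)methyl)carbamoyl, with its six-membered aromatic ring and 10 heavy atoms, gives way to the ringless (methoxycarbonyl)amino with 5 heavy atoms, although the pyridine-bearing group gives the lower number. Both groups have the same counts of hydrogen-bond donors and acceptors, so the change removes the ring and shrinks the group without altering those counts, and no measurement at hand explains the size of the step.

This single step cannot separate the loss of the ring from the loss of size, or from the switch from a carbonyl carbon to a nitrogen as the atom attached to the aromatic ring. From the compounds shown here alone, a benzylcarbamoyl group, a plain primary amide or a carboxylic acid on the same carbon would help to tell these apart, and their effect on binding remains open.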